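The source may hold more compounds than are shown below. What is called first, only, known or untested is meant among the compounds shown, and "the series" means these compounds.

Two compounds share one core and differ only in the ring attached to the sulfonyl sulfur. Compound 1, `O=S(=O)(c1cccc(F)c1)c1cn(C2CCNC2)c2ncccc12`, carries a 3-fluorophenyl there and gives 44% in a functional assay on HeLa cells for agonist activity at 5-hydroxytryptamine receptor 6 (Homo sapiens), read by cAMP accumulation and immunoassay; a lower number here means a smaller maximal response, a higher number a larger maximal response. Compound 2, `O=S(=O)(c1ccc(F)cc1)c1cn(C2CCNC2)c2ncccc12`, carries a 4-fluorophenyl and gives 50% in this assay. For the measured compounds named here, the only measured step, a number 6 percentage points higher from compound 1 to compound 2 (within the scatter), shows that swapping 4-fluorophenyl for 3-fluorophenyl changed little. Compound 2 holds the higher of the two numbers, but its gap to compound 1 is within the scatter, so the two cannot be ranked.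

Compound 3, `O=S(=O)(c1cccc(Br)c1)c1cn(C2CCNC2)c2ncccc12`, has not yet been measured. The change from compound 2 is 3-bromophenyl in place of 4-fluorophenyl on a sulfonyl sulfur. Going by the values given here, the measured step bears on this only in part: read backwards, a number 6 percentage points higher from compound 1 to compound 2 (within the scatter) covers a return from 4-fluorophenyl to a ring substituted in the 3-position, while the exchange of fluorine for bromine has no measured counterpart. Because a number 6 percentage points higher from compound 1 to compound 2 (within the scatter) stayed within the scatter, a step of about a number 5 percentage points lower from compound 2 to compound 3 (within the scatter) is expected, that is, none beyond the scatter. Compound 3 is therefore estimated at 45%, within a range of 30% to 60%.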

Compound 3, largest response reached (Emax), in percent of the reference or control that the assay uses: 49%
Compound 3: the middle estimate sits 4 percentage points below what was measured; the range from low to high includes it.
By their numbers in this assay, from the lowest: compounds 1, 3 and 2 (each within the scatter of the next).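

Bromo in place of fluoro on an aromatic carbon gave a number 5 percentage points higher from compound 1 to compound 3 (within the scatter) in this assay, which is the first measured exchange of one halogen for another on this ring. Changing the halogen and its place on the ring together, 3-bromophenyl in place of 4-fluorophenyl on the sulfonyl sulfur, gave a number 1 percentage points lower from compound 2 to compound 3 (within the scatter), so the three rings tried on this sulfur give maximal responses that cannot be told apart. No measurement is available that would explain this outcome.

As far as these compounds go, all three compounds carry a phenyl ring with a single halogen on the sulfonyl sulfur, so it remains open how the maximal response would look with an unsubstituted phenyl, a methoxyphenyl or a naphthyl group there. From the compounds shown here alone, it also remains open whether a chloro group on the ring would fit the same picture, and whether any replacement on this sulfur can move the number beyond the scatter.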